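Cytotoxicity notes: fluoro to trifluoromethyl on the aryl ring

A few compounds are considered here, and "the series" means these few. Any claim that something is new, unique, unknown or untested is made for them only; others in the source may bear on it.

Measured compounds:
- compound 1, `CC(=O)OC[C@H]1O[C@H](OC[C@@H](Cn2cc(CN(c3nc(-c4ccc(F)cc4)no3)C3CCCCC3)nn2)OC(C)=O)C=C[C@@H]1OC(C)=O`: 28.8 ug/mL
- compound 2, `C#CCN(c1nc(-c2ccc(Br)cc2)no1)C1CCCCC1`: 102 ug/mL

Two compounds have numbers in an ADME assay on HepG2 cells (Homo sapiens) for cytotoxicity, read by MTT assay, with a stated time of 48 h; a higher number here means that more compound is tolerated, a lower number that less compound is tolerated. Compound 1 gives 28.8 ug/mL and stands lowest of the two; the nearest is compound 2 with 102 ug/mL, a gap beyond the scatter, so less of compound 1 is tolerated than of compound 2. Within the data shown here, the two compounds differ in many places at once, and no single-change step between them is available, so the gap cannot be assigned to any one part of the structure.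

Compound 3, `CC(=O)OC[C@H]1O[C@H](OC[C@@H](Cn2cc(CN(c3nc(-c4ccc(C(F)(F)F)cc4)no3)C3CCCCC3)nn2)OC(C)=O)C=C[C@@H]1OC(C)=O`, is the one not yet measured in this assay . It differs from compound 1 in a single place: trifluoromethyl in place of fluoro on an aromatic carbon, on an aromatic carbon of a six-membered aromatic ring of carbon only, para to a large group. Among the measured compounds shown here, no step of this kind, fluoro to trifluoromethyl, has been measured, so there is no internal reference for its size. The expectation for compound 3 is a step of a 1.3-fold lower number from compound 1 to compound 3 (0.12 log units; within the scatter), i.e. no change beyond the scatter or at most a modest move toward less tolerated. Compound 3 is estimated at 22 ug/mL, with a range from 10 ug/mL to 50 ug/mL.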

Compound 3, half-maximal cytotoxic concentration: 81.4 ug/mL
For compound 3 the middle estimate is 3.7-fold (0.57 log units) below the measured one, and the stated range ends below it.
By their numbers in this assay, from the lowest: compound 1; then compounds 3 and 2 (each within the scatter of the next).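

The series now has its first single-place step in this assay: trifluoromethyl in place of fluoro on an aromatic carbon, para to a large group, gives a 2.8-fold higher number from compound 1 to compound 3 (0.45 log units; beyond the scatter). This place on the six-membered aromatic ring is therefore not indifferent to what it carries: with the rest of the structure unchanged, going from 4-fluorophenyl to 4-(trifluoromethyl)phenyl moves the number toward more compound tolerated, and by more than the scatter. Nothing measured alongside these numbers speaks to what lies behind the step.

Among these compounds, with only one change at this place, it remains open whether the direction belongs to trifluoromethyl alone or would also appear with another group there, such as a nitrile, a methoxy group or an amine. On these data alone, compound 2 carries bromo at the corresponding place but differs in many other places as well, so it neither supports nor tests the step, and whether a step of this size would recur on a different core also stays open.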